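Replacing (2-aminoethyl)amino in compound 2 with (4-fluorobenzyl)oxy

The source may report more compounds than this note shows. Statements on the series, on what has been measured and on what is new or still open speak of the compounds shown alone.

Compound 1 `CCn1c(C(=O)NCCN)ccc1C(CC)(CC)c1ccc(OCC(=O)C(C)(C)C)c(C)c1`: 2500 nM
Compound 2 `CCn1c(C(=O)NCCN)ccc1C(CC)(CC)c1ccc(OCC(O)C(C)(C)C)c(C)c1`: 2400 nM
Compound 3 `CCn1c(C(=O)N(C)CC(=O)O)ccc1C(CC)(CC)c1ccc(OCC(=O)C(C)(C)C)c(C)c1`: 8700 nM

All three compounds were tested in an ADME assay on L02 cells (Homo sapiens) for cytotoxicity, read by MTT assay, with a stated time of 48 h; on this read-out higher numbers stand for weaker inhibition and lower numbers for stronger inhibition. Compound 2 gives 2400 nM, and it stands level with its closest neighbour within the scatter, as a 1.0-fold lower number from compound 1 to compound 2 (0.02 log units; within the scatter) shows. Compound 3 gives a clearly higher number, at 8700 nM.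

The next compound is compound 4 `CCn1c(C(=O)OCc2ccc(F)cc2)ccc1C(CC)(CC)c1ccc(OCC(O)C(C)(C)C)c(C)c1`, which keeps the rest of compound 2 but changes one group: (4-fluorobenzyl)oxy in place of (2-aminoethyl)amino on a carbonyl carbon. In words, (4-fluorobenzyl)oxy comes in place of (2-aminoethyl)amino on a carbonyl carbon.

One measured step removes the same (2-aminoethyl)amino from the same carbonyl carbon, and it is modest: a 3.5-fold higher number from compound 1 to compound 3 (0.54 log units; beyond the scatter). For the measured compounds named here, the entering group there is (carboxymethyl)(methyl)amino, however, and no measured compound carries (4-fluorobenzyl)oxy, so this precedent is only a loose guide. The other step, a 1.0-fold lower number from compound 1 to compound 2 (0.02 log units; within the scatter), concerns the hydroxy group that compound 4 retains, and it offers no reason to expect a shift from that part.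

A modest rise is therefore expected, in the same direction as the precedent. The estimated change is a 2.5-fold higher number from compound 2 to compound 4 (0.40 log units; beyond the scatter). The expected value for compound 4 is 6000 nM, with an estimated range from 1800 nM to 20000 nM.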

Compound 4, half-maximal inhibitory concentration: 14900 nM
Compound 4: middle estimate off by 2.5-fold (0.40 log units), on the low side; the measured number falls inside the stated range.
By their numbers in this assay, from the lowest: compounds 2 and 1 (each within the scatter of the next); then compounds 3 and 4 (each within the scatter of the next).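

In this assay, the position on the carbonyl carbon proves sensitive to a second, quite different replacement: (4-fluorobenzyl)oxy in place of (2-aminoethyl)amino gives a 6.2-fold higher number from compound 2 to compound 4 (0.79 log units; beyond the scatter), on the background that carries the 1-hydroxy-2,2-dimethylpropyl group. Together with a 3.5-fold higher number from compound 1 to compound 3 (0.54 log units; beyond the scatter), on the background that carries the (tert-butyl)carbonyl group, this means that both listed departures from (2-aminoethyl)amino move the number the same way, towards weaker inhibition, although one entering group keeps a nitrogen on the carbonyl carbon and the other puts an oxygen there, with a six-membered aromatic ring and no hydrogen-bond donors. Nothing in the information at hand explains why the number rises at this position.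

The compounds shown leave open whether the rise follows the oxygen on the carbonyl carbon, the loss of the terminal amine or the fluorinated benzyl ring, and a (4-fluorobenzyl)amino group or an unsubstituted benzyloxy group on the same carbon would begin to separate these. They also leave open how a shorter or longer aminoalkyl chain, or a free carboxylic acid at this carbonyl, would read in this assay.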